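The source may report more compounds than this note shows. Statements on the series, on what has been measured and on what is new or still open speak of the compounds shown alone.

Measured compounds:
- compound 1 `C#CCC(O)(c1ccc(N2CCN(S(=O)(=O)c3ccc(N)nc3)C[C@@H]2C#CC)cc1)C(F)(F)F`: 130 nM
- compound 2 `CC#C[C@H]1CN(S(=O)(=O)c2ccc(N)nc2)CCN1c1ccc(S(N)(=O)=O)cc1`: 37 nM
- compound 3 `CC#C[C@H]1CN(S(=O)(=O)c2ccc(N)nc2)CCN1c1ccc(C(O)(CC#N)C(F)(F)F)cc1`: 219 nM

These values come from an assay on cells (Hepatocyte) for inhibition of glucokinase regulatory protein (Mus musculus), with stated times of 20 min and 40 min; a higher number here means that more compound is needed for the effect, a lower number that less compound is needed. Compound 3 gives the highest number of the three; it sits near compound 1, within the scatter, and furthest from compound 2, as a 5.9-fold higher number from compound 2 to compound 3 (0.77 log units; beyond the scatter) shows. Compound 4 `CC#C[C@H]1CN(S(=O)(=O)c2ccc(N)nc2)CCN1c1ccc(S(=N)(=O)C2CC2)cc1` differs from compound 3 by a group of 6 heavy atoms (3 carbon, 1 nitrogen, 1 oxygen, 1 sulfur; one three-membered non-aromatic ring of carbon only) in place of a group of 9 heavy atoms (4 carbon, 1 nitrogen, 1 oxygen, 3 fluorine; no ring), on an aromatic carbon. Among the compounds with values here, two measured steps bear on this position: a 3.5-fold lower number from compound 1 to compound 2 (0.55 log units; beyond the scatter) and a 5.9-fold higher number from compound 2 to compound 3 (0.77 log units; beyond the scatter), both modest and beyond the scatter, and both point to a lower number when the fluorine-bearing chain is exchanged for a sulfur-bearing group there. Compound 4 carries a sulfur-bearing group again, so a lower number is expected, estimated as a 4.0-fold lower number from compound 3 to compound 4 (0.60 log units; beyond the scatter). Compound 4 is thus expected to give about 55 nM, within 15 nM to 180 nM.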

Compound 4, half-maximal effective concentration: 208 nM
Compound 4: the middle estimate sits 3.8-fold (0.58 log units) below what was measured, outside the stated range (above it).
By their numbers in this assay, from the lowest: compound 2; then compounds 1, 4 and 3 (each within the scatter of the next).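

In this assay, a sulfur-bearing group at this position does not guarantee a lower number: a 1.1-fold lower number from compound 3 to compound 4 (0.02 log units; within the scatter) and a 1.6-fold higher number from compound 1 to compound 4 (0.20 log units; within the scatter) both stay within the scatter, whereas a 5.6-fold higher number from compound 2 to compound 4 (0.75 log units; beyond the scatter) is beyond it. What counts here is therefore the particular sulfur-bearing group, not the presence of sulfur alone. Nothing available explains this gap. Going by these compounds, whether the three-membered carbon ring contributes to it remains open. So does how an amine or a carboxylic acid on this aromatic carbon would compare.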